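This account rests on a few compounds, and the source may have more. Where it says the series, first, only, none or still open, it means among the compounds named here.

Measured compounds in a functional assay on HCT-116 cells (Homo sapiens) for antiproliferative activity; a higher number here means that more compound is needed for the effect, a lower number that less compound is needed:

- compound 1, `Cc1c2c(n3c1CC(=O)NCCCNc1cc-3ccc1C(N)=O)CC(C)(C)CC2=O`, gives "not determined" (no result reported)
- compound 2, `CC(=O)NCCN1CC[C@H](C)Nc2cc(ccc2C(N)=O)-n2c(c(C)c3c2CC(C)(C)CC3=O)CC1=O`, reaches only the assay limit > 5000 nM
- compound 3, `Cc1c2c(n3c1CC(=O)N(C)CC[C@H](C)Nc1cc-3ccc1C(N)=O)CC(C)(C)CC2=O`, gives 247 nM

Among the compounds with values here, compound 3 holds the only actual number seen in this assay; compound 2 stands at a limit rather than a number, and compound 1 carries no result at all. Within the data shown here, the one step that can be read, an at least 20-fold lower number from compound 2 to compound 3 (1.30 log units; beyond the scatter), shows how strongly this assay responded to trimming a side group from the ring chain, with the line the limit of > 5000 nM in this assay, at which 1 of the 3 values shown sits, marking that compound 2 sits at the edge of what the assay can report.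

Compound 4, `Cc1c2c(n3c1CC(=O)NCC[C@H](C)Nc1cc-3ccc1C(N)=O)CC(C)(C)CC2=O`, differs from compound 3 in a single place: hydrogen in place of methyl on an amide-type nitrogen in a ring. Among the measured compounds shown here, no measured pair changes the same place, so the one step seen concerns a different position and only shows that the ring chain is sensitive to what hangs on it. With nothing pointing in a clear direction, a shift no larger than the usual scatter is expected, a 1.2-fold higher number from compound 3 to compound 4 (0.08 log units; within the scatter). Compound 4 is therefore estimated at 300 nM, within a range from 100 nM to 1000 nM.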

Compound 4, half-maximal effective concentration in the HCT-116 assay: 815 nM
Beside the measured number, compound 4's estimate is 2.7-fold (0.43 log units) below it; low and high end bracket the measured number.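

The nitrogen that carries the methyl group now proves to matter on its own in the HCT-116 assay: removing that methyl gives a 3.3-fold higher number from compound 3 to compound 4 (0.52 log units; beyond the scatter), while a much longer substituent on the same nitrogen is worse than hydrogen, with an at least 6.1-fold lower number from compound 2 to compound 4 (0.78 log units; beyond the scatter), a step that rests on a limit for compound 2, not on a number. Among hydrogen, methyl and 2-acetamidoethyl, methyl therefore gives the lowest number, so this nitrogen responds in both directions rather than simply favouring less or more substitution. In a physicochemical assay for solubility (on this read-out lower numbers stand for lower solubility and higher numbers for higher solubility), compound 3 gives > 100 ug/mL, which is a limit, and in the physicochemical assay compound 4 gives > 100 ug/mL, also a limit, so the step between them cannot be read: the limit of > 100 ug/mL in the physicochemical assay, at which 2 of the 2 values shown sit.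

On these data alone, with only these three groups on this nitrogen, it remains open how an ethyl group, a cyclopropyl group or a chain ending in an amine would fare in the HCT-116 assay. Also open, as far as these compounds go, is how far compound 3 and compound 4 lie beyond their limits in the physicochemical assay, and whether they differ there at all.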